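This account rests on a few compounds, and the source may have more. Where it says the series, first, only, none or still open, it means among the compounds named here.

Measured in a functional assay on A549 cells (Homo sapiens), read by MTT assay, with a stated time of 72 h; a higher number here means a weaker inhibitor, a lower number a stronger inhibitor:
Compound 1 `CNc1ncnc2c1c(-c1ccoc1)cn2[C@@H]1O[C@H](CO)[C@@H](O)[C@H]1O`: > 20000 nM
Compound 2 `CNc1ncnc2c1c(-c1cccs1)cn2[C@@H]1O[C@H](CO)[C@@H](O)[C@H]1O`: > 20000 nM

Compound 2 gives > 20000 nM, and this is a limit of the assay, not a number. Compound 1 gives > 20000 nM, which is also a limit. Compound 2 therefore sits at the limit of > 20000 nM in this assay, at which 2 of the 2 values shown sit, and no rank can be given to it.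

Compound 3 `CNc1ncnc2c1c(-c1ccsc1)cn2[C@@H]1O[C@H](CO)[C@@H](O)[C@H]1O` has thiophen-3-yl in place of thiophen-2-yl on an aromatic carbon of the shared core: thiophen-3-yl in place of thiophen-2-yl on an aromatic carbon. The two have the same atoms, joined differently.

Within the data shown here, the one measured step that bears on this exchange is a step that the two limits leave unreadable from compound 1 to compound 2, with thiophen-2-yl in place of furan-3-yl. It offers no size to carry over, only the observation that neither of these two compounds gave a number. On the evidence of compound 2 at the limit of > 20000 nM in this assay, at which 2 of the 2 values shown sit, no step beyond the scatter is expected in this assay, and no direction can be favoured. The estimated step is a number no higher from compound 2 to compound 3 (the limit leaves the size open). Compound 3 is expected at 20000 nM, with an estimated range of 8000 nM to 40000 nM, and the assay may well report only a limit.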

Compound 3, half-maximal inhibitory concentration: > 20000 nM
Compound 3: only a limit was reported; the forecaster's own chance of this, stated with the estimate: 85%; the middle value sits exactly at the limit.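

In this assay compound 3 gives > 20000 nM, which is a limit of the assay and not a number. No step among compound 1, compound 2 and compound 3 can be read: the limit of > 20000 nM in this assay, at which 3 of the 3 values shown sit.

The compounds shown leave open whether the furan-3-yl, thiophen-2-yl and thiophen-3-yl groups differ at all in this assay.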